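The source may report more compounds than this note shows. Statements on the series, on what has been measured and on what is new or still open speak of the compounds shown alone.

Series notes. For the measured compounds named here, compound 1 `CN(C)CCCCCSC1=Nc2ccccc2C(CC(=O)NCc2ccc(F)cc2)N1c1ccc(-c2ccccc2)cc1` and compound 2 `CN(C)CCCCCSC1=Nc2ccccc2C(CC(=O)NCc2ccccc2)N1c1ccc(-c2ccc(F)cc2)cc1` are the two members measured so far in an assay on cells for inhibition of Voltage-dependent T-type calcium channel subunit alpha-1G (Homo sapiens), read by patch clamp; a higher number here means a weaker inhibitor, a lower number a stronger inhibitor. In this assay compound 1 gives 27400 nM, the highest of the two numbers; compound 2 gives 250 nM, a lower number, with the gap between the two lying beyond the scatter of repeated runs. The next member, compound 3 `CN(C)CCCCCSC1=Nc2ccccc2C(CC(=O)NCc2ccc(F)cc2)N1c1ccccc1`, is not yet measured. It differs from compound 1 in one place: hydrogen in place of phenyl on an aromatic carbon, the same difference cut one bond further out reading 4-phenylphenyl to phenyl. Going by the values given here, no measured pair shows this change by itself, so the direction is open. The working expectation is a small step, from compound 1 to compound 3 of a 1.2-fold higher number from compound 1 to compound 3 (0.07 log units; within the scatter), not clearly beyond the scatter and if anything toward a weaker inhibitor. Compound 3 is accordingly estimated at 32000 nM in this assay, within a range of 8000 nM to 100000 nM.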

Compound 3, half-maximal inhibitory concentration: 555000 nM
Compound 3: the middle estimate sits 17-fold (1.24 log units) below what was measured; measured number above the stated range.
By their numbers in this assay, from the lowest: compound 2; then compound 1; then compound 3.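

Hydrogen in place of phenyl on an aromatic carbon, para to a large group, is a large loss in this assay (a 20-fold higher number from compound 1 to compound 3 (1.31 log units; beyond the scatter)), so this position is far from indifferent to the change, at least in this pair. For the compounds shown here, compound 1 and compound 2 both carry an outer aromatic ring here, so neither could show what its removal costs; compound 3 gives the first reading of that, with compound 3 as the weaker inhibitor of the pair. Nothing at hand explains the size of this step.

On these data alone, it remains open whether a full phenyl ring is needed at this carbon, or whether a methyl group, a chlorine atom, a pyridyl ring or a cyclohexyl ring would keep part of the number seen with phenyl. Whether the step has the same size with an unsubstituted benzyl amide also stays unsettled.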